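From Methyl to Pentyl on the Phenyl Substituent

The source may hold more compounds than are shown below. What is called first, only, known or untested is meant among the compounds shown, and "the series" means these compounds.

Two compounds carry measurements so far. Compound 1 `O=C1O[C@H]([C@@H](O)Cn2cc(-c3ccc(Br)cc3)nn2)C(OCc2ccccc2)=C1OCc1ccccc1` gives 3910 nM in a functional assay on HeLa cells (Homo sapiens) for antiproliferative activity, read by MTT assay, with a stated time of 72 h; on this read-out higher numbers stand for weaker inhibition and lower numbers for stronger inhibition. Compound 2 `Cc1ccc(-c2cn(C/C=C3\OC(=O)C(OCc4ccccc4)=C3OCc3ccccc3)nn2)cc1` gives 7480 nM in this assay. Of these two numbers, compound 2 stands highest; its nearest neighbour is compound 1, whose number is lower by an amount that falls within the scatter of repeated measurements, so the two cannot be told apart on these data.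

Compound 3 `CCCCCc1ccc(-c2cn(C/C=C3\OC(=O)C(OCc4ccccc4)=C3OCc3ccccc3)nn2)cc1` has not been measured. It differs from compound 2 in one place: butyl in place of hydrogen on a saturated chain carbon bound to an aromatic carbon, so that the 4-methylphenyl group becomes a 4-pentylphenyl group. Going by the values given here, no measured pair in this set shows what such a lengthening does, so nothing here fixes the direction. Any step toward a lower number would be expected to stay modest, of a size comparable to the scatter rather than clearly beyond it. On that basis compound 3 is expected to give about 4000 nM in this assay, with a plausible range from 1500 nM to 12000 nM. That expectation corresponds to a 1.9-fold lower number from compound 2 to compound 3 (0.27 log units; within the scatter).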

Compound 3, half-maximal inhibitory concentration: > 100000 nM
Compound 3 gave a limit, no number; the forecaster's own chance of this, stated with the estimate: 5%; at least 25-fold (1.39 log units) between middle value and limit.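

This one change at a single place is enough to move the result sharply: going from the 4-methylphenyl group to the 4-pentylphenyl group, with the rest of the molecule untouched, gives an at least 13-fold higher number from compound 2 to compound 3 (1.12 log units; beyond the scatter) in this assay. Going by these compounds alone, until now, no pair of compounds showed what a substituent at this place could do, and this pair shows that the read-out is far from indifferent to the length of the chain there, at least when it goes from methyl to pentyl. For compound 3 the result is a limit of the assay and not a number, so this step marks how far the activity fell without giving its exact size: the limit of > 100000 nM in this assay, at which 1 of the 3 values shown sits.

Going by these compounds, with only the two ends of the series in hand, it remains open whether a shorter chain such as ethyl or propyl would already bring the number up or whether the change sets in only near pentyl. On these data alone, it is equally open how a pentyl chain ending in an amine or a carboxylic acid would behave, and these data give no reason for the loss seen with the plain chain.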